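A few compounds are considered here, and "the series" means these few. Any claim that something is new, unique, unknown or untested is made for them only; others in the source may bear on it.

Measured compounds:
- compound 1, `CCOC(=O)CN(C)C(=O)c1ccc(C(CC)(CC)c2ccc(OCCC(O)(CC)CC)c(C)c2)n1CC`: 520 nM
- compound 2, `CCn1c(C(=O)NC(CC(=O)O)C(=O)OC)ccc1C(CC)(CC)c1ccc(OCCC(O)(CC)CC)c(C)c1`: 26 nM

Both were tested in an assay on cells for agonist activity at vitamin D3 receptor (Homo sapiens), with a stated time of 96 h; on this read-out higher numbers stand for an effect only at larger amounts of compound and lower numbers for an effect already at smaller amounts. Among the measured compounds shown here, compound 2 has the lower number of the two, and its only neighbour is compound 1, with a 20-fold lower number from compound 1 to compound 2 (1.30 log units; beyond the scatter). That single step changed the group on the carbonyl carbon, turning a tertiary amide into a secondary one that carries a carboxylic acid and a methyl ester.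

Compound 3, `CCn1c(C(=O)NC(CO)CCO)ccc1C(CC)(CC)c1ccc(OCCC(O)(CC)CC)c(C)c1`, keeps the secondary amide of compound 2 but changes its substituent: a group of 6 heavy atoms (4 carbon, 2 oxygen; no ring) in place of a group of 9 heavy atoms (5 carbon, 4 oxygen; no ring), on an amide-type nitrogen. The acid and the ester leave; two hydroxyl groups enter. For the measured compounds named here, no measured pair shows this change alone. The step from compound 1 to compound 2 is the only one that bears on it, and it mixed two alterations at once, so it gives only a loose guide. Because the gain seen in a 20-fold lower number from compound 1 to compound 2 (1.30 log units; beyond the scatter) came together with the acid that compound 3 no longer carries, part of it is expected to be lost, and the step of a 4.2-fold higher number from compound 2 to compound 3 (0.63 log units; beyond the scatter) is expected to be moderate and upward. Compound 3 is therefore estimated at 110 nM, within 30 nM to 400 nM.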

Compound 3, half-maximal effective concentration: 2490 nM
Estimate against measurement, compound 3: 23-fold (1.35 log units) below; the measured number lies above the stated range.
By their numbers in this assay, from the lowest: compound 2; then compound 1; then compound 3.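

In this assay, keeping the secondary amide does not keep the low number: placing 3-hydroxy-1-(hydroxymethyl)propyl on the amide-type nitrogen gives a 96-fold higher number from compound 2 to compound 3 (1.98 log units; beyond the scatter) with the rest of the molecule unchanged. This position therefore responds strongly to what is attached there, and the low number of compound 2 cannot be credited to the secondary amide alone. The new group also compares poorly with the tertiary amide, as a 4.8-fold higher number from compound 1 to compound 3 (0.68 log units; beyond the scatter) shows, so that change on the carbonyl carbon does not by itself produce a gain. The compounds shown offer no measurement that explains why this group behaves as it does.

From the compounds shown here alone, it remains open which part of the group in compound 2 matters, since its carboxylic acid and methyl ester leave together in the step to compound 3. A group carrying only the carboxylic acid, only the methyl ester, or a single hydroxyl on the same chain would help to separate these contributions, and an amine in that place would test a different kind of group.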